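Phenyl for methyl on the shared core of compound 2

A few compounds are considered here, and "the series" means these few. Any claim that something is new, unique, unknown or untested is made for them only; others in the source may bear on it.

Of the compounds shown here, three have been measured in an assay for binding affinity to Indoleamine 2,3-dioxygenase 1 (Homo sapiens), read by spectrophotometry, with a stated time of 30 min; on this read-out lower numbers stand for tighter binding and higher numbers for weaker binding. Compound 1 `C[Si](C)(C)c1cccc2[nH]ncc12` gives 43000 nM. Compound 2 `Cc1cc(C(O)Cc2ccccc2)c2cn[nH]c2c1` gives 470 nM and stands lowest of the three numbers; the nearest to it is compound 3 `CCc1cc(C(O)Cc2ccccc2)c2cn[nH]c2c1`, which gives 740 nM, and the furthest is compound 1. For the measured compounds named here, the only one-place step among the measured compounds, a 1.6-fold higher number from compound 2 to compound 3 (0.20 log units; within the scatter), concerns methyl in place of hydrogen on a saturated chain carbon bound to an aromatic carbon, and it is within the scatter.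

Compound 4 `OC(Cc1ccccc1)c1cc(-c2ccccc2)cc2[nH]ncc12` is not yet measured. Against compound 2 it shows (phenyl in place of methyl on an aromatic carbon), that is, phenyl in place of methyl on an aromatic carbon. Going by the values given here, no measured step covers a change of this kind; the step from compound 2 to compound 3 is the nearest comparison, since it also enlarges the group at this part of the core, and it stayed within the scatter. The change to phenyl is larger than that one, so the expectation is wider on both sides but with no clear direction.

Compound 4 is therefore expected to give about 700 nM in this assay, within a range of 200 nM to 2500 nM. This estimate corresponds to a step of a 1.5-fold higher number from compound 2 to compound 4 (0.17 log units; within the scatter), expected to lie within the scatter.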

Compound 4, dissociation constant: 53000 nM
For compound 4 the middle estimate is 76-fold (1.88 log units) below the measured one, outside the stated range (above it).
By their numbers in this assay, from the lowest: compounds 2 and 3 (each within the scatter of the next); then compounds 1 and 4 (each within the scatter of the next).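

In this assay this aromatic carbon, meta to a fused ring and meta to the group of 9 heavy atoms, is not indifferent to its substituent: methyl and ethyl had differed only within the scatter (a 1.6-fold higher number from compound 2 to compound 3 (0.20 log units; within the scatter)), but phenyl in place of methyl gives a large loss (a 110-fold higher number from compound 2 to compound 4 (2.05 log units; beyond the scatter)). The step from ethyl is also large (a 72-fold higher number from compound 3 to compound 4 (1.86 log units; beyond the scatter)), so the two alkyl compounds stand together and the break in this set comes with the move to the aromatic ring, not with the first addition to the methyl group. Nothing at hand accounts for this break, so the size of the step is recorded without an explanation.

The compounds shown do not separate the presence of a ring from the overall size of the group, and cyclopropyl, cyclohexyl or a longer chain such as propyl or butyl on this carbon would help draw that line. On these data alone, it also remains open whether a phenyl ring carrying an amine or a carboxylic acid would stay as weak as compound 4 or recover towards compound 2.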